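This account rests on a few compounds, and the source may have more. Where it says the series, first, only, none or still open, it means among the compounds named here.

Measured compounds and their values in a functional assay on PC-3 cells (Homo sapiens) for antiproliferative activity, read by MTT assay, with a stated time of 48 h; on this read-out higher numbers stand for weaker inhibition and lower numbers for stronger inhibition:
compound 1 `CC1(C)Cc2c(ccc(C(=O)/C=C/c3ccccc3)c2OCc2ccccc2)O1` gives > 100000 nM.
compound 2 `CC1(C)Cc2c(O)ccc(C(=O)/C=C/c3cn(-c4ccccc4)nc3-c3cccc([N+](=O)[O-])c3)c2O1` gives 25600 nM.
compound 3 `CC1(C)Cc2c(OCc3ccccc3)ccc(C(=O)/C=C/c3ccc(Br)cc3)c2O1` gives > 100000 nM.

The value of compound 1 is not a number but a limit of this assay. The value of compound 3 is also such a limit. So compound 1 stands at the weak end of what has been seen here, with compound 2 the only measured compound that gives a number. Of the three values shown, two sit at that limit, which is what the limit of > 100000 nM in this assay, at which 2 of the 3 values shown sit, records.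

The step from compound 1 to compound 4 `CC1(C)Cc2c(ccc(C(=O)/C=C/c3ccc(F)cc3)c2OCc2ccccc2)O1` is small on paper: fluoro in place of hydrogen on an aromatic carbon. Within the data shown here, nothing in the measured set links a single change of this kind to a change in this assay, since no two measured compounds differ in just one place. What the set does show is that compound 1 and compound 3, which share the same core, both give only a limit. On that basis no shift beyond the scatter is expected from compound 1 to compound 4, in either direction, and compound 4 is most likely to come back as a limit again.

Among the measured compounds shown here, the expected value for compound 4 in this assay is 100000 nM, with a range from 40000 nM to 300000 nM; this means an expected step of a number no higher from compound 1 to compound 4 (the limit leaves the size open), which is no step at all beyond the scatter.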

Compound 4, half-maximal inhibitory concentration: 44200 nM
The estimate for compound 4 lay 2.3-fold (0.35 log units) above the measured number, within the range that was stated.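

In this assay, putting fluoro in place of hydrogen on an aromatic carbon, para to a large group, turns phenyl into 4-fluorophenyl and gives an at least 2.2-fold lower number from compound 1 to compound 4 (0.35 log units; beyond the scatter). Among these compounds, this is the first single change in the set whose effect can be read, and it shows that one added fluorine atom at this position is enough to go with a shift beyond the usual scatter, towards stronger inhibition. Compound 1 gives > 100000 nM, which is a limit and not a number, so the step has a known smallest size but no known full size, and its starting point is a value shared with another compound: the limit of > 100000 nM in this assay, at which 2 of the 4 values shown sit.

Whether this shift is specific to fluoro stays open, as the compounds shown include no chloro, methoxy or amine group at this same position on the core of compound 1. They also leave open how large the same change would be on a compound that starts from a measured number rather than a limit.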